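Lengthening the chain of a nitroimidazole-bearing compound

The source may report more compounds than this note shows. Statements on the series, on what has been measured and on what is new or still open speak of the compounds shown alone.

Measured so far:
- compound 1 `COc1cc2c(Nc3ccc(F)c(Cl)c3)ncnc2cc1OCCCn1ccnc1[N+](=O)[O-]` gives 5910 nM
- compound 2 `COc1cc2c(Nc3cccc(Br)c3)ncnc2cc1OCCCn1ccnc1[N+](=O)[O-]` gives 13500 nM
- compound 3 `COc1cc2c(Nc3cccc(Br)c3)ncnc2cc1OCCCCCCn1ccnc1[N+](=O)[O-]` gives 30200 nM

In a functional assay on A549 cells (Homo sapiens) for inhibition, read by sulforhodamine B assay, with a stated time of 72 h (on this read-out lower numbers stand for stronger inhibition and higher numbers for weaker inhibition), compound 2, at 13500 nM, holds the middle place of the three numbers. Compound 4 `COc1cc2c(Nc3cccc(Br)c3)ncnc2cc1OCCOCCn1ccnc1[N+](=O)[O-]` is not yet measured. It differs from compound 2 as follows: 2-(2-nitro-1H-imidazol-1-yl)ethoxy in place of (2-nitro-1H-imidazol-1-yl)methyl on a saturated chain carbon, two bonds along the chain from an oxygen on an aromatic ring. The 3-bromophenyl group stays unchanged. Two measured steps are available. One is a 2.3-fold higher number from compound 1 to compound 2 (0.36 log units; beyond the scatter), but it concerns another part of the molecule and says little here. The closer guide is the other change made on this chain, a 2.2-fold higher number from compound 2 to compound 3 (0.35 log units; beyond the scatter). Among the compounds with values here, that single modest rise is the only evidence for the chain, and no measured compound carries the 2-(2-nitro-1H-imidazol-1-yl)ethoxy group. Within the data shown here, a small upward move in this assay is therefore expected, no larger than that step. The estimate means a 1.5-fold higher number from compound 2 to compound 4 (0.17 log units; within the scatter), an expected change that may stay close to the scatter. Compound 4 is expected at about 20000 nM, with an estimated range from 9000 nM to 42000 nM.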

Compound 4, half-maximal inhibitory concentration: 13000 nM
For compound 4 the middle estimate is 1.5-fold (0.19 log units) above the measured one; the range from low to high includes it.
By their numbers in this assay, from the lowest: compound 1; then compounds 4 and 2 (each within the scatter of the next); then compound 3.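

In this assay, placing 2-(2-nitro-1H-imidazol-1-yl)ethoxy on this chain gives a 1.0-fold lower number from compound 2 to compound 4 (0.02 log units; within the scatter) and so leaves the number in place, although the entering group holds 11 heavy atoms where the leaving group holds 9. The earlier chain change, a 2.2-fold higher number from compound 2 to compound 3 (0.35 log units; beyond the scatter), lay beyond the scatter, so a larger group at this position does not always go with a higher number in this assay. Nothing available here explains why these two chain changes differ.

Still open, from the compounds shown here alone, is whether an amine nitrogen in place of the chain oxygen, or a longer chain carrying a second ether oxygen, would likewise stay within the scatter of compound 2. Going by these compounds, it is also open whether the 2-(2-nitro-1H-imidazol-1-yl)ethoxy group would behave the same way alongside the 3-chloro-4-fluorophenyl group of compound 1.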